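The source may hold more compounds than are shown below. What is called first, only, known or untested is meant among the compounds shown, and "the series" means these compounds.

Three compounds have been measured in a functional assay on 502713 cells (Homo sapiens) for inhibition, read by trypan blue exclusion, with a stated time of 48 h; on this read-out lower numbers stand for stronger inhibition and higher numbers for weaker inhibition:

- Compound 1 `CCCCCCC[C@@H](C/C=C/CCC(=O)N1CCCCC1)OC`: > 100000 nM
- Compound 2 `CCCCCCC[C@H](C/C=C/CCC(=O)N1CCCCC1)OC`: > 100000 nM
- Compound 3 `CCCCCCC[C@H](O)C/C=C/CCC(=O)NCC(C)C`: > 100000 nM

Each of these entries is a limit and not a number. All three compounds stand at the same place: the limit of > 100000 nM in this assay, at which 3 of the 3 values shown sit. The data therefore cannot rank compound 3 against the other two.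

Compound 4 `CCCCCCC[C@H](O)C/C=C/CCC(=O)N1CCCC1` differs from compound 3 in one place: pyrrolidin-1-yl in place of isobutylamino on a carbonyl carbon. In short, pyrrolidin-1-yl takes the place of isobutylamino on a carbonyl carbon.

Going by the values given here, only one measured step connects two compounds, a step that the two limits leave unreadable from compound 1 to compound 2. Its size cannot be read, and it concerns a different kind of change: the fact that compounds 1 and 2 differ only in the configuration as drawn. Among the compounds with values here, no measured pair makes the swap on the carbonyl carbon, so the evidence for this change is indirect and thin.

The expectation rests on compound 3, whose > 100000 nM is a limit. No step beyond the usual scatter is expected in this assay, and no direction can be argued, so compound 4 will most likely be reported as a limit too. The expected step is a step that the limit leaves unreadable from compound 3 to compound 4.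

For compound 4 the estimate is 120000 nM, with an expected range from 40000 nM to 300000 nM.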

Compound 4, half-maximal inhibitory concentration: > 100000 nM
Compound 4 was reported as a limit; the forecaster's own chance of this, stated with the estimate: 75%; the middle value is on the limit's open side.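

In this assay compound 4 gives > 100000 nM as a limit and not a number. Compound 3 also stands at a limit, so no size can be read for the change from compound 3 to compound 4. How strongly any of these compounds inhibits the cells stays open, since all share one place: the limit of > 100000 nM in this assay, at which 4 of the 4 values shown sit.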